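The source may hold more compounds than are shown below. What is called first, only, known or untested is meant among the compounds shown, and "the series" means these compounds.

Measured so far in an assay on isolated protein for inhibition of Death-associated protein kinase 3 (Homo sapiens), tested at 10 uM; a lower number here means a weaker effect, a higher number a stronger effect of the compound at the concentration tested:
- compound 1 `COc1ccc(C2=N/C(=C\c3cccnc3)C(=O)O2)cc1OC`: in this assay compound 1 gives 36%
- compound 2 `O=C1OC(c2cccc(Br)c2)=N/C1=C\c1cccnc1`: in this assay compound 2 gives 100%

For the measured compounds named here, compound 2 stands highest of the two numbers in this assay; the only other value, that of compound 1, lies well below it, and the gap between the two is beyond the usual scatter. Compound 2 thus marks the top of this small series.

Compound 3 `COc1cccc(C2=N/C(=C\c3cccnc3)C(=O)O2)c1` has not been measured. Relative to compound 2 the change is methoxy in place of bromo on an aromatic carbon. Going by the values given here, no measured pair shows this single change on its own, so the step cannot be read off directly. Among the compounds with values here, the one compound that carries methoxy on that ring, compound 1, gives 36% in this assay, but it differs from compound 2 in more than one place, so its value can only be taken as a loose pointer.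

On this basis a loss from compound 2 to compound 3 in this assay is expected, beyond the scatter but not all the way down to compound 1, estimated as a number 38 percentage points lower from compound 2 to compound 3 (beyond the scatter). Compound 3 is expected to give about 62% in this assay, within a range of 30% to 92%.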

Compound 3, a percentage reported as inhibition, at one concentration (the size of the read-out at that concentration, not a potency): 100%
Compound 3: middle estimate off by 38 percentage points, on the low side, and the stated range ends below it.
By their numbers in this assay, from the lowest: compound 1; then compounds 2 and 3 (each within the scatter of the next).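

In this assay, the aromatic carbon meta to a large group accepts methoxy in place of bromo with the effect intact, the step reading no change at the digits printed from compound 2 to compound 3 (within the scatter), so bromo is not needed there for the read-out at the concentration tested. The low value of compound 1 therefore cannot be pinned on methoxy at this carbon, since compound 3 carries methoxy on this ring and keeps the effect. For the compounds shown here, the methoxy that compound 1 carries and compound 3 lacks is the one tied to the loss: hydrogen in its place on an aromatic carbon gives a number 64 percentage points higher from compound 1 to compound 3 (beyond the scatter), which makes that second site, not the one changed between compound 2 and compound 3, the sensitive place in this small set. No data at hand explain either step.

As far as these compounds go, this percentage shows only the size of the effect at the one concentration tested, so whether compound 2 and compound 3 would differ at any other concentration stays open. Also open, from the compounds shown here alone, is whether the tolerance at this carbon extends beyond these two groups, for instance to an amine, a carboxylic acid or a longer alkoxy chain.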